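Fluoro for Methoxy: Expected Antiproliferative Potency of Compound 4

A few compounds are considered here, and "the series" means these few. Any claim that something is new, unique, unknown or untested is made for them only; others in the source may bear on it.

Measured so far in a functional assay on A-431 cells (Homo sapiens) for antiproliferative activity, read by sulforhodamine B assay, with a stated time of 72 h; on this read-out lower numbers stand for stronger inhibition and higher numbers for weaker inhibition:
compound 1 `C=C1CC(CBr)(c2ccccc2OC)OC1=O`: 2400 nM
compound 2 `C=C1CC(CBr)(c2ccc(OC)cc2)OC1=O`: 4200 nM
compound 3 `C=C1CC(CBr)(c2ccccc2F)OC1=O`: 1700 nM

Compound 1 and compound 2 have the same atoms joined differently; the difference between the two cores is not broken down here. Compound 3 differs from compound 1 by fluoro in place of methoxy on an aromatic carbon, and this gave a 1.4-fold lower number from compound 1 to compound 3 (0.15 log units; within the scatter). Compound 4 `C=C1CC(CBr)(c2ccc(F)cc2)OC1=O` has not been measured; it differs from compound 2 by fluoro in place of methoxy on an aromatic carbon. This is the same kind of change, not the same: in compound 3 the fluoro stands ortho to a group of 9 heavy atoms, in compound 4 it stands para to a group of 9 heavy atoms. Because a 1.4-fold lower number from compound 1 to compound 3 (0.15 log units; within the scatter) lay within the scatter, the expected step in this assay for compound 4 is similarly small, namely a 1.4-fold lower number from compound 2 to compound 4 (0.15 log units; within the scatter). On that basis compound 4 is estimated at 3000 nM, with a likely range from 1300 nM to 7000 nM.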

Compound 4, half-maximal inhibitory concentration: 800 nM
For compound 4 the middle estimate is 3.8-fold (0.57 log units) above the measured one, and the stated range ends above it.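

In this assay, the new step is a 5.3-fold lower number from compound 2 to compound 4 (0.72 log units; beyond the scatter), and it shows that the size of this change did not carry over from one core to the other: the same change on two cores in this assay, a 1.4-fold lower number (0.15 log units; within the scatter) from compound 1 to compound 3 and a 5.3-fold lower number (0.72 log units; beyond the scatter) from compound 2 to compound 4, 3.7-fold (0.57 log units) apart, beyond the scatter of two such steps. Among these compounds, the earlier step, a 1.4-fold lower number from compound 1 to compound 3 (0.15 log units; within the scatter), is the smaller of the two, so only the step with the fluoro para to a group of 9 heavy atoms stands clear of the scatter. With one pair on each core, the data do not show what lies behind the gap, nor how the change would behave on a further core.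

Open, on these data alone, is how a chloro, an amine or a longer ether chain on that aromatic carbon would read in this assay. Also open, as far as these compounds go, is whether the larger step would hold with a methyl in place of the bromomethyl group.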